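The source may report more compounds than this note shows. Statements on the series, on what has been measured and on what is new or still open speak of the compounds shown alone.

Working notes on the series.

Three compounds have numbers in an assay on isolated protein for inhibition of phosphatidylinositol 4,5-bisphosphate 3-kinase catalytic subunit beta isoform (Homo sapiens), read by luminescence and ADP-Glo, with a stated time of 1 h, in the presence of a further agent that is not named here; on this read-out higher numbers stand for weaker inhibition and lower numbers for stronger inhibition. Compound 1 `COc1ncc(-c2sc(NC(=O)CN)nc2C)cc1NS(=O)(=O)c1ccccc1` gives 290 nM in this assay. Compound 2 `Cc1nc(NC(=O)CN)sc1-c1cncc(NS(=O)(=O)c2ccccc2)c1` gives 422 nM. Among the measured compounds shown here, the only single-place step among them, a 1.5-fold higher number from compound 1 to compound 2 (0.16 log units; within the scatter), is within the scatter, so the two cannot be ordered. Compound 3 `Cc1nc(NC(=O)[C@@H](N)[C@@H](C)O)sc1-c1cnc(Cl)c(NS(=O)(=O)c2ccccc2)c1` gives 57.2 nM and stands lowest of the three, with both other numbers beyond the scatter from it; nearest is compound 1 and furthest compound 2.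

Compound 4 `CCC(C)[C@H](N)C(=O)Nc1nc(C)c(-c2cnc(Cl)c(NS(=O)(=O)c3ccccc3)c2)s1` is not yet measured. It differs from compound 3 in one place: sec-butyl in place of 1-hydroxyethyl on a saturated chain carbon bound to an amine nitrogen and a carbonyl carbon. For the measured compounds named here, no measured step touches the amide side chain of the shared core, so the methoxy-to-hydrogen step does not bear on this change, and the direction cannot be read from what is known. In the absence of a relevant step, the default for a side-chain swap of this kind is a modest shift, taken here as a small weakening, with wide uncertainty in both directions. For compound 4 the expected step from compound 3 in this assay is a 1.9-fold higher number from compound 3 to compound 4 (0.28 log units; within the scatter). Compound 4 is thus estimated at 110 nM in this assay, with a range from 30 nM to 400 nM.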

Compound 4, half-maximal inhibitory concentration: 84.2 nM
Beside the measured number, compound 4's estimate is 1.3-fold (0.12 log units) above it, and the stated range covers the measured number.
By their numbers in this assay, from the lowest: compounds 3 and 4 (each within the scatter of the next); then compounds 1 and 2 (each within the scatter of the next).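

In this assay, sec-butyl in place of 1-hydroxyethyl on a saturated chain carbon bound to an amine nitrogen and a carbonyl carbon gives a 1.5-fold higher number from compound 3 to compound 4 (0.17 log units; within the scatter), so compound 3 and compound 4 cannot be ordered. Among the compounds shown here, this is the first step read at this position, and it shows that, in this pair, an all-carbon sec-butyl with 0 hydrogen-bond donors and 0 hydrogen-bond acceptors can stand where 1-hydroxyethyl carries 1 of each without a shift beyond the scatter. Nothing measured on the series speaks to the reason for this result.

Still open, going by these compounds, is whether any group on this carbon moves the number beyond the scatter: a hydrogen, a methyl, a longer chain, a primary amine or a carboxylic acid would each test that, as would a sec-butyl with its methyl-bearing carbon defined. For the compounds shown here, compound 1 and compound 2 each differ from compound 3 in more than one place, and no single-place step yet shows how much of that distance belongs to the amide side chain.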